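From oxolan-3-yl to oxan-4-yl on the side chain

The compounds below may be only part of what the source reports. "The series", "measured", "known", "first", "only" and "open" are said of these compounds alone.

Measured so far in a functional assay on HT-29 cells (Homo sapiens) for inhibition, read by luminescence and CellTiter-Glo, with a stated time of 24 h (on this read-out lower numbers stand for an effect already at smaller amounts and higher numbers for an effect only at larger amounts of compound), are:
Compound 1 `CCn1nc(C(=O)N[C@H]2COc3ccccc3N(C)C2=S)nc1Cc1ccccc1` gives 17 nM
Compound 2 `CN1C(=S)[C@@H](NC(=O)c2nc(Cc3ccccc3)n(CC3CCOC3)n2)COc2ccccc21` gives 4420 nM

Of these two, compound 2 holds the higher number. Going by the values given here, compound 3 `CN1C(=S)[C@@H](NC(=O)c2nc(Cc3ccccc3)n(CC3CCOCC3)n2)COc2ccccc21` has not been measured and carries oxan-4-yl in place of oxolan-3-yl on a saturated chain carbon bound to an aromatic nitrogen as its only difference from compound 2. Among the compounds with values here, one measured step bears on this place, a 260-fold higher number from compound 1 to compound 2 (2.41 log units; beyond the scatter) as methyl gives way to oxolan-3-yl, and it is large. Within the data shown here, no measured step compares ring sizes, so no step beyond the scatter is expected in this assay and no direction can be given. The expected change is a 1.1-fold lower number from compound 2 to compound 3 (0.04 log units; within the scatter) by this estimate. For compound 3 the estimated value is 4000 nM with an expected range from 700 nM to 20000 nM on this reasoning.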

Compound 3, half-maximal effective concentration: 6310 nM
Estimate against measurement, compound 3: 1.6-fold (0.20 log units) below, within the range that was stated.
By their numbers in this assay, from the lowest: compound 1; then compounds 2 and 3 (each within the scatter of the next).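

In this assay, changing the ring of this side group from oxolan-3-yl to oxan-4-yl makes no readable difference, giving a 1.4-fold higher number from compound 2 to compound 3 (0.15 log units; within the scatter). The large gap to methyl is seen with the six-membered ring as well, at a 370-fold higher number from compound 1 to compound 3 (2.57 log units; beyond the scatter), so it is not confined to oxolan-3-yl. Nothing at hand explains this gap.

Going by these compounds, whether a longer plain chain, a cyclohexyl ring or an amine such as piperidin-4-yl at this place would read close to compound 1 or close to compound 3 remains open.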